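Removing a fluorine from an inactive amide

This account rests on a few compounds, and the source may have more. Where it says the series, first, only, none or still open, it means among the compounds named here.

Compound 1 `O=C(Nc1ccc(Cl)c(-c2nnc3c(Cl)cccn23)c1)c1cccc(Cl)c1`: in a functional assay on HeLa cells (Homo sapiens) for antiproliferative activity, read by MTT assay, with a stated time of 72 h (a lower number here means a stronger inhibitor, a higher number a weaker inhibitor), compound 1 gives a limit, > 100000 nM.
Compound 2 `O=C(Nc1ccc(Cl)c(-c2nnc3c(Cl)cccn23)c1)c1c(F)cccc1Cl`: in this assay compound 2 gives a limit, > 100000 nM.
Compound 3 `O=C(Nc1ccc(Cl)c(-c2nnc3c(Cl)cccn23)c1)c1ccccc1Cl`: not yet measured.

Compound 2 stands at the limit, as the limit of > 100000 nM in this assay, at which 2 of the 2 values shown sit, records. Compound 3 differs from compound 2 by hydrogen in place of fluoro on an aromatic carbon. Among the measured compounds shown here, the only measured step, a step that the two limits leave unreadable from compound 1 to compound 2, is unreadable, so it sets no size for this change. Because the limit of > 100000 nM in this assay, at which 2 of the 2 values shown sit, holds both measured compounds at the limit, compound 3 is expected to remain near it. The expected step is a number no higher from compound 2 to compound 3 (the limit leaves the size open). Compound 3 is estimated at 100000 nM, within 30000 nM to 300000 nM.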

Compound 3, half-maximal inhibitory concentration: > 100000 nM
Compound 3 gave a limit, no number (the forecaster's own chance of this, stated with the estimate: 80%); the middle value sits exactly at the limit.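

Compound 1, compound 2 and compound 3 all stop at a limit, so no step between them can be read: the limit of > 100000 nM in this assay, at which 3 of the 3 values shown sit.

The compounds shown leave open how far apart these three truly lie in this assay, and which change would give a readable number.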